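Allyl to prenyl ether on a thiazolidinedione series

The compounds below may be only part of what the source reports. "The series", "measured", "known", "first", "only" and "open" are said of these compounds alone.

Compound 1 `COc1cc(/C=C2\SC(=O)NC2=O)ccc1OCC1(C)CCc2c(C)c(OCC=C(C)C)c(C)c(C)c2O1`: 78%
Compound 2 `C=CCOc1c(C)c(C)c2c(c1C)CCC(C)(COc1ccc(/C=C3\SC(=O)NC3=O)cc1Br)O2`: 98%

In a functional assay on MCF7 cells (Homo sapiens), tested at 5 uM (on this read-out lower numbers stand for a stronger effect and higher numbers for a weaker effect at the one concentration tested), compound 2 gives the highest of the two numbers, with compound 1 as nearest neighbour a step below it that lies beyond the scatter. Compound 3 `CC(C)=CCOc1c(C)c(C)c2c(c1C)CCC(C)(COc1ccc(/C=C3\SC(=O)NC3=O)cc1Br)O2` is compound 2 with one change: 2-methylprop-1-en-1-yl in place of vinyl on a saturated chain carbon bound to an oxygen on an aromatic ring. For the measured compounds named here, no single-change step between measured compounds is known here, so the step is estimated from compound 1 only loosely. The expected step is a small one, a number 8 percentage points lower from compound 2 to compound 3 (within the scatter), towards a stronger effect. Compound 3 is therefore expected to give about 90%, within a range from 72% to 100%.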

Compound 3, a percentage reported as activity, at one concentration (the size of the read-out at that concentration, not a potency): 84%
The estimate for compound 3 lay 6 percentage points above the measured number; measured number inside the range.
By their numbers in this assay, from the lowest: compounds 1 and 3 (each within the scatter of the next); then compound 2.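

For the compounds shown here, exchanging allyl for 3-methylbut-2-en-1-yl gives the first single-change reading at this position in this assay, which is a number 14 percentage points lower from compound 2 to compound 3 (beyond the scatter) and shows that this ether chain affects the read-out. Bromo in place of methoxy on an aromatic carbon gives a number 6 percentage points higher from compound 1 to compound 3 (within the scatter) and leaves compound 1 and compound 3 indistinguishable.

Going by these compounds, whether a benzyl group or a carboxylic acid at this place would give a different read-out remains open, as does whether the allyl to 3-methylbut-2-en-1-yl step holds with methoxy on the aromatic carbon. No measurement shown here explains either step.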